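Removing the Imidazole from a Furyl Pyrimidine Aniline Series

A few compounds are considered here, and "the series" means these few. Any claim that something is new, unique, unknown or untested is made for them only; others in the source may bear on it.

Measured compounds:
Compound 1 `c1cc(Nc2nccc(-c3ccco3)n2)cc(-n2ccnc2)c1` gives 800 nM
Compound 2 `CCc1cccc(Nc2nccc(-c3ccco3)n2)c1` gives 9700 nM
Compound 3 `c1cc(Nc2nccc(-c3ccco3)n2)cc(OCCn2ccnc2)c1` gives 200 nM

In a functional assay for inhibition, with Homo sapiens as the target (on this read-out lower numbers stand for stronger inhibition and higher numbers for weaker inhibition), compound 3 holds the lowest number of the three, its nearest neighbour being compound 1 and its furthest compound 2. Compound 4 `COc1cccc(Nc2nccc(-c3ccco3)n2)c1` differs from compound 3 by hydrogen in place of (1H-imidazol-1-yl)methyl on a saturated chain carbon bound to an oxygen on an aromatic ring. Going by the values given here, two measured steps bear on this. Swapping the imidazole-bearing group for a plain alkyl gave a 12-fold higher number from compound 1 to compound 2 (1.08 log units; beyond the scatter), and the reverse direction gave a 49-fold lower number from compound 2 to compound 3 (1.69 log units; beyond the scatter). Losing the imidazole from compound 3 is therefore expected to raise the number in this assay by a large step, an 18-fold higher number from compound 3 to compound 4 (1.24 log units; beyond the scatter). Compound 4 is accordingly estimated at 3500 nM, with a range from 1000 nM to 12000 nM.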

Compound 4, half-maximal inhibitory concentration: 400 nM
The estimate for compound 4 lay 8.8-fold (0.94 log units) above the measured number, and the stated range ends above it.
By their numbers in this assay, from the lowest: compounds 3, 4 and 1 (each within the scatter of the next, the first and the last beyond it); then compound 2.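

In this assay the imidazole turns out not to be needed at this position: cutting 2-(1H-imidazol-1-yl)ethoxy back to methoxy leaves the two numbers within the scatter (a 2.0-fold higher number from compound 3 to compound 4 (0.30 log units; within the scatter)), and methoxy also stands level with 1H-imidazol-1-yl (a 2.0-fold lower number from compound 1 to compound 4 (0.30 log units; within the scatter)). Going by these compounds alone, the large separation from ethyl, earlier seen only with imidazole-bearing groups, is thus also reached by a group with no imidazole (a 24-fold lower number from compound 2 to compound 4 (1.38 log units; beyond the scatter)). The compounds shown leave open whether a hydroxyl, an amine or a longer alkoxy chain at this place would match methoxy. No evidence is available to explain these steps.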